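The compounds below may be only part of what the source reports. "The series", "measured", "known", "first", "only" and "open" are said of these compounds alone.

In a physicochemical assay for solubility, in phosphate buffer, with a stated time of 24 h, at pH 7.4, tested at 200 uM (a lower number here means a less soluble compound, a higher number a more soluble compound), compound 1 `Cc1cc(-c2ccc3ccc(C(=O)c4ccc(F)c(O)c4)nc3c2)ccc1O` gives 13000 nM, while compound 2 `O=C(c1ccc(F)c(O)c1)c1ccc2ccc(-c3nnn[nH]3)cc2n1` gives 50000 nM, the higher of the two numbers. Compound 3 `O=C(O)CNc1ccc2ccc(C(=O)c3ccc(F)c(O)c3)nc2c1` carries (carboxymethyl)amino in place of 1H-tetrazol-5-yl on an aromatic carbon. For the measured compounds named here, only one measured step bears on this, the modest 3.8-fold higher number from compound 1 to compound 2 (0.59 log units; beyond the scatter), which involves the leaving group. Going by the values given here, no measured step involves the entering group. A small upward move that stays within the scatter is therefore expected, and the estimated change is a 1.2-fold higher number from compound 2 to compound 3 (0.08 log units; within the scatter). In this assay, compound 3 is expected to give 60000 nM, with an estimated range of 20000 nM to 180000 nM.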

Compound 3, solubility: > 200000 nM
Compound 3 ended at the assay's limit (the forecaster's own chance of this, stated with the estimate: 10%); at least 3.3-fold (0.52 log units) between middle value and limit.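

Compound 3 sits at a limit of the assay, not at a number: the limit of > 200000 nM in this assay, at which 1 of the 3 values shown sits.

At this aromatic carbon, a group with no ring moves the number further than 1H-tetrazol-5-yl did, with an at least 4.0-fold higher number from compound 2 to compound 3 (0.60 log units; beyond the scatter). Measured against 4-hydroxy-3-methylphenyl, the same group gives an at least 15-fold higher number from compound 1 to compound 3 (1.18 log units; beyond the scatter), so this position has more range than the first step showed.

As far as these compounds go, whether a plain amine or a longer chain ending in a carboxylic acid would do the same remains open. From the compounds shown here alone, the true size of both steps also stays open.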